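A few compounds are considered here, and "the series" means these few. Any claim that something is new, unique, unknown or untested is made for them only; others in the source may bear on it.

The measured compounds:
compound 1, `Cc1cc(CNCc2ccc(Cl)cc2)c(C)n1-c1ccc(Cl)cc1`, which gives 18 ug/mL;
compound 2, `Cc1c(CN2CCN(C3CC4CCC3C4)CC2)cc(-c2ccc(Cl)cc2)n1-c1ccc(Cl)cc1`, which gives 429 ug/mL.

Both numbers come from an ADME assay on THP-1 cells (Homo sapiens) for cytotoxicity, read by trypan blue exclusion, with a stated time of 48 h; on this read-out higher numbers stand for weaker inhibition of growth and lower numbers for stronger inhibition of growth. Of the two, compound 1 stands on the lowest number, meaning the strongest inhibition of growth seen here; the nearest is compound 2, whose number is higher by an amount beyond the usual scatter. Compound 3, `Cc1cc(CNOCc2ccccc2)c(C)n1-c1ccc(Cl)cc1`, has not yet been measured. It differs from compound 1 in one place: benzyloxy in place of 4-chlorobenzyl on an amine nitrogen. Within the data shown here, no measured pair shows a change of this kind, so the expectation rests on compound 1 alone and on the fact that the group leaving and the group entering carry the same count of heavy atoms. The step of a 1.7-fold higher number from compound 1 to compound 3 (0.22 log units; within the scatter) is expected to be small, at most a modest rise in the number, and may not go beyond the scatter. Compound 3 is therefore estimated at 30 ug/mL, with a range from 10 ug/mL to 90 ug/mL.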

Compound 3, concentration for 50% growth inhibition: 67 ug/mL
For compound 3 the middle estimate is 2.2-fold (0.35 log units) below the measured one; the range from low to high includes it.
By their numbers in this assay, from the lowest: compound 1; then compound 3; then compound 2.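

Among these compounds, this is the first measured step at this amine nitrogen: in this assay, benzyloxy in place of 4-chlorobenzyl gives a 3.7-fold higher number from compound 1 to compound 3 (0.57 log units; beyond the scatter) and so weaker inhibition of growth. The position therefore responds to this change, even though the leaving and entering groups carry the same count of heavy atoms and the same kind of aromatic ring, so that count alone does not settle the number here. No measurement shown explains the rise.

The change removes a chlorine and adds an oxygen in a single step, so the compounds shown cannot tell which of the two matters, or whether both do. A plain benzyl group or a 4-chlorobenzyloxy group on this nitrogen would separate the two parts of the change.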